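Chain-end variation around compound 1

The compounds below may be only part of what the source reports. "The series", "measured", "known", "first", "only" and "open" are said of these compounds alone.

Measured so far, in a functional assay, read by fluorescence and spectrophotometry, with a stated time of 1 h; on this read-out lower numbers stand for an effect already at smaller amounts and higher numbers for an effect only at larger amounts of compound:
- compound 1 `CCCCCCS(=O)(=O)/C=C/c1ccc(O)c(O)c1`: 7300 nM
- compound 2 `O=S(=O)(/C=C/c1ccc(O)c(O)c1)CCC1CCCC1`: 6800 nM
- compound 3 `CCCCCCCCS(=O)(=O)/C=C/c1ccc(O)c(O)c1`: 6400 nM

Compound 1 holds the highest of the three numbers, but the three sit together: the nearest step is a 1.1-fold lower number from compound 1 to compound 2 (0.03 log units; within the scatter) and the furthest is a 1.1-fold lower number from compound 1 to compound 3 (0.06 log units; within the scatter), both within the scatter. The remaining step, a 1.1-fold lower number from compound 2 to compound 3 (0.03 log units; within the scatter), is within the scatter too. Nothing among these three separates the chain variants on this read-out.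

Compound 4 `C=CCCCCCS(=O)(=O)/C=C/c1ccc(O)c(O)c1` differs from compound 1 in one place: vinyl in place of methyl on a saturated chain carbon, five bonds along the chain from a sulfonyl sulfur. Within the data shown here, the step that bears most directly on it is the one from compound 1 to compound 3, which also lengthens the chain at the same end, and that step was within the scatter; the steps involving compound 2 point the same way. The expected step is therefore a 1.0-fold lower number from compound 1 to compound 4 (0.02 log units; within the scatter), in no set direction. For compound 4 the estimate in this assay is 7000 nM, with a range from 3500 nM to 14000 nM.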

Compound 4, half-maximal effective concentration: 7100 nM
Estimate against measurement, compound 4: 1.0-fold (0.01 log units) below, within the range that was stated.
By their numbers in this assay, from the lowest: compounds 3, 2, 4 and 1 (each within the scatter of the next).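

Adding a double bond outside aromatic rings at this chain end, with vinyl in place of methyl five bonds along the chain from a sulfonyl sulfur, gives a 1.0-fold lower number from compound 1 to compound 4 (0.01 log units; within the scatter) in this assay. The unsaturated chain end is also not separated from the saturated chain ends of the other two compounds, with a 1.1-fold higher number from compound 3 to compound 4 (0.05 log units; within the scatter) and a 1.0-fold higher number from compound 2 to compound 4 (0.02 log units; within the scatter). All four compounds therefore remain within the scatter of one another on this read-out, now across a straight saturated, a cyclopentyl-bearing and a terminally unsaturated chain end, and no supporting data bear on this result.

Still open, on these data alone, is whether an amine or a carboxylic acid at this chain end would separate from these compounds. The same holds for a much shorter or much longer chain.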